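Replacing the Sulfonyl Cap with a Carbonyl Cap

The source may hold more compounds than are shown below. What is called first, only, known or untested is meant among the compounds shown, and "the series" means these compounds.

Two members of this series have been measured in a functional assay on SK-MEL-28 cells (Homo sapiens) for cytotoxicity, read by MTT assay; a higher number here means a weaker inhibitor, a lower number a stronger inhibitor. Compound 1 `COc1ccc(S(=O)(=O)NCCCNc2nccc(-c3c(-c4cccc(F)c4)nc4sccn34)n2)cc1` gives 8980 nM, and compound 2 `O=S(=O)(NCCNc1nccc(-c2c(-c3cccc(F)c3)nc3sccn23)n1)c1ccc(F)cc1` gives 9450 nM. Compound 1 carries the lower of the two numbers, but the gap is within the scatter, so the two cannot be told apart. Compound 3 `O=C(NCCCNc1nccc(-c2c(-c3cccc(F)c3)nc3sccn23)n1)c1ccc(F)cc1` awaits a value in this assay. It differs from compound 1 in one place: (4-fluorophenyl)carbonyl in place of (4-methoxyphenyl)sulfonyl on an amine nitrogen. Going by the values given here, no measured pair isolates this change, so no recorded step is available for it. With both measured numbers close together and weak, the step from compound 1 to compound 3 is expected to stay within the scatter in either direction, and a step of about a 1.1-fold lower number from compound 1 to compound 3 (0.02 log units; within the scatter) is estimated. Compound 3 is therefore expected to give roughly 8500 nM in this assay, with a range of 3000 nM to 25000 nM.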

Compound 3, half-maximal inhibitory concentration: > 20000 nM
Compound 3: no number, only a limit; the forecaster's own chance of this, stated with the estimate: 10%; middle value at least 2.3-fold (0.37 log units) from the limit.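

Compound 3 gives > 20000 nM in this assay, a limit of the assay and not a number. The cap on this amine nitrogen is not a silent position, as the series now shows an at least 2.2-fold higher number from compound 1 to compound 3 (0.34 log units; beyond the scatter), and the second comparison shows an at least 2.1-fold higher number from compound 2 to compound 3 (0.32 log units; beyond the scatter); on these compounds, the sulfonyl-capped members keep a measurable value and the carbonyl-capped member does not. How large either step really is stays unknown, with only a lower bound on each: the limit of > 20000 nM in this assay, at which 1 of the 3 values shown sits.

The change swaps the sulfonyl for carbonyl and the aryl substituent together, so the contribution of each cannot be separated here. Going by these compounds, a (4-methoxyphenyl)carbonyl cap on the same chain would separate them, and a longer chain or a terminal amine in place of the capped nitrogen remains open.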